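A few compounds are considered here, and "the series" means these few. Any claim that something is new, unique, unknown or untested is made for them only; others in the source may bear on it.

In a functional assay on HT-29 cells (Homo sapiens) for cytotoxicity, read by MTT assay, with a stated time of 72 h (a higher number here means a weaker inhibitor, a lower number a stronger inhibitor), compound 3 (`Cc1ccc2nc(NC(=O)c3cn(-c4ccccc4)nc3-c3ccc(Cl)cc3)sc2c1`) gives 23700 nM as its reading. That reading lies within the scatter of compound 1 (`O=C(Nc1nc2ccccc2s1)c1cn(-c2ccccc2)nc1-c1ccc(Cl)cc1`) at 13700 nM. Compound 2 (`O=C(Nc1nc2ccc(F)cc2s1)c1cn(-c2ccccc2)nc1-c1ccc(Cl)cc1`) gives 4970 nM in the same test. Compound 3 sits on the weaker side of compound 2, and that gap lies beyond the scatter.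

Compound 4 (`COc1ccc(-c2nn(-c3ccccc3)cc2C(=O)Nc2nc3ccc(C)cc3s2)cc1`) differs from compound 3 in one place, where 4-chlorophenyl becomes 4-methoxyphenyl (methoxy in place of chloro on an aromatic carbon). This puts methoxy in place of chloro on an aromatic carbon.

Within the data shown here, no measured compound varies this group. The steps at hand all lie elsewhere on the shared core and can only suggest how far one small substitution has moved this read-out. The step of a 1.7-fold higher number from compound 1 to compound 3 (0.24 log units; within the scatter) stays within the scatter, while a 2.8-fold lower number from compound 1 to compound 2 (0.44 log units; beyond the scatter) and a 4.8-fold higher number from compound 2 to compound 3 (0.68 log units; beyond the scatter) are modest. None of them gives a direction for the new change.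

In this assay a modest step at most is therefore expected, in either direction, and the best guess is none beyond the scatter. The expected step is small (a 1.1-fold lower number from compound 3 to compound 4 (0.03 log units; within the scatter)) on this estimate. For compound 4 the estimated value is 22000 nM (expected range 8000 nM to 55000 nM).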

Compound 4, half-maximal inhibitory concentration: 21500 nM
Compound 4: the middle estimate sits 1.0-fold (0.01 log units) above what was measured; low and high end bracket the measured number.
By their numbers in this assay, from the lowest: compound 2; then compounds 1, 4 and 3 (each within the scatter of the next).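

In this assay, the step of a 1.1-fold lower number from compound 3 to compound 4 (0.04 log units; within the scatter) is the only one shown at this position, and it places 4-methoxyphenyl in for 4-chlorophenyl without a difference beyond the scatter. The earlier compounds shown here varied only a distant part of the shared core, whereas this pair shows that the reading holds when chloro, with 1 heavy atom and 0 hydrogen-bond acceptors, gives way to methoxy, with 2 heavy atoms and 1 hydrogen-bond acceptor, on an aromatic carbon para to a large group. Nothing available accounts for this outcome, and this single pair cannot show whether the position is generally indifferent to substitution.

Going by these compounds, it remains open whether the same exchange would read alike on the fluoro-bearing core of compound 2, whose number is the lowest of the series, rather than on the methyl-bearing core of compound 3. Also open, on these data alone, is whether an amine, a carboxylic acid or a longer chain in place of chloro or methoxy would produce a step beyond the scatter in this read-out, and in which direction.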